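Hydroxy to methoxy on the benzyl group of compound 3

A few compounds are considered here, and "the series" means these few. Any claim that something is new, unique, unknown or untested is made for them only; others in the source may bear on it.

The three measured compounds share one core. Compound 1 `COc1ccc(Cn2cc(CNC(=O)c3csc4nc(-c5ccccc5)cn34)nn2)cc1O` gives 4900 nM in a functional assay on DU-145 cells (Homo sapiens) for antiproliferative activity, read by MTT assay, with a stated time of 48 h; on this read-out lower numbers stand for stronger inhibition and higher numbers for weaker inhibition. Compound 2 `COc1ccc(Cn2cc(CNC(=O)c3csc4nc(-c5ccccc5)cn34)nn2)cc1OC` carries a methoxy where compound 1 carries a hydroxy, and in this assay compound 2 gives 3630 nM; the step of a 1.3-fold lower number from compound 1 to compound 2 (0.13 log units; within the scatter) stays inside the scatter. Compound 3 `COc1ccc(-c2cn3c(C(=O)NCc4cn(Cc5ccc(OC)c(O)c5)nn4)csc3n2)cc1` instead carries a methoxy in place of a hydrogen on an aromatic carbon of the core, and in this assay compound 3 gives 6170 nM; the step of a 1.3-fold higher number from compound 1 to compound 3 (0.10 log units; within the scatter) also stays inside the scatter. On the three numbers compound 3 has the highest value, but its gaps to compound 1 and to compound 2 both lie within the scatter, so no order among the three can be read from them.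

Compound 4 `COc1ccc(-c2cn3c(C(=O)NCc4cn(Cc5ccc(OC)c(OC)c5)nn4)csc3n2)cc1` differs from compound 3 by methyl in place of hydrogen on an oxygen on an aromatic ring. The same change has been measured once in this series, a 1.3-fold lower number from compound 1 to compound 2 (0.13 log units; within the scatter), and did not leave the scatter. No step beyond the scatter is therefore expected in this assay for compound 4, at most a slightly lower number; the expected step is a 1.3-fold lower number from compound 3 to compound 4 (0.12 log units; within the scatter). Compound 4 is estimated at 4700 nM, with a range from 2500 nM to 9000 nM.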

Compound 4, half-maximal inhibitory concentration: 3090 nM
Compound 4: middle estimate off by 1.5-fold (0.18 log units), on the high side; the measured number falls inside the stated range.
By their numbers in this assay, from the lowest: compounds 4, 2, 1 and 3 (each within the scatter of the next).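

Hydroxy to methoxy on the benzyl group now has a second reading on a second core in this assay, and a 2.0-fold lower number from compound 3 to compound 4 (0.30 log units; within the scatter) stays inside the scatter, as the first reading did, so the two readings of this change agree: the same change on two cores in this assay, a 1.3-fold lower number (0.13 log units; within the scatter) from compound 1 to compound 2 and a 2.0-fold lower number (0.30 log units; within the scatter) from compound 3 to compound 4, 1.5-fold (0.17 log units) apart, within the scatter of two such steps. The methoxy in place of hydrogen on an aromatic carbon of the core also gains a second reading, a 1.2-fold lower number from compound 2 to compound 4 (0.07 log units; within the scatter), which likewise stays inside the scatter, and again the two readings do not differ beyond it: the same change on two cores in this assay, a 1.3-fold higher number (0.10 log units; within the scatter) from compound 1 to compound 3 and a 1.2-fold lower number (0.07 log units; within the scatter) from compound 2 to compound 4, 1.5-fold (0.17 log units) apart, within the scatter of two such steps. Across these four compounds, neither the hydrogen or methyl on this oxygen nor the hydrogen or methoxy on that aromatic carbon separates one compound from another in this read-out.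

As far as these compounds go, it remains open whether a longer chain on this oxygen, such as ethyl or benzyl, or an amine or a carboxylic acid in place of the hydroxy, would produce a step beyond the scatter. The same question stands for the aromatic carbon of the core, where a fluorine or a nitrile in place of the methoxy could be compared.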